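The source may hold more compounds than are shown below. What is called first, only, known or untested is meant among the compounds shown, and "the series" means these compounds.

In a functional assay, read by spectrophotometry, with a stated time of 10 min (on this read-out higher numbers stand for an effect only at larger amounts of compound and lower numbers for an effect already at smaller amounts), three compounds have been measured so far. Compound 1 `O=C1Nc2ccccc2/C1=[N+](\[O-])c1ccccc1` gives 1300 nM, compound 2 `O=C1Nc2ccc([N+](=O)[O-])cc2/C1=[N+](\[O-])Cc1ccccc1` gives 1000 nM, and compound 3 `O=C1Nc2ccccc2/C1=[N+](\[O-])Cc1ccccc1` gives 1800 nM. Compound 3 thus stands within the scatter of both other compounds, so these three numbers offer no ranking.

Compound 4 `CN1C(=O)/C(=[N+](/[O-])Cc2ccccc2)c2ccccc21` differs from compound 3 in a single place: methyl in place of hydrogen on an amide-type nitrogen in a ring. In words, it has methyl in place of hydrogen on an amide-type nitrogen in a ring.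

For the measured compounds named here, only one measured step changes a single place, a 1.8-fold higher number from compound 2 to compound 3 (0.26 log units; within the scatter), and it stays within the scatter. That step replaces nitro with hydrogen on an aromatic carbon, so it bears on the new change only indirectly. Going by the values given here, no measured compound carries a group other than hydrogen on the amide-type nitrogen, so the data hold no direct test of this change.

Among the compounds with values here, with that single step as the only guide, no step beyond the scatter is expected in this assay, and the uncertainty remains wide. The expected result is a 1.1-fold higher number from compound 3 to compound 4 (0.05 log units; within the scatter). For compound 4 the estimated value is 2000 nM, with an expected range from 600 nM to 6000 nM.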

Compound 4, half-maximal effective concentration: 600 nM
Estimate against measurement, compound 4: 3.3-fold (0.52 log units) above, within the range that was stated.
By their numbers in this assay, from the lowest: compounds 4, 2, 1 and 3 (each within the scatter of the next, the first and the last beyond it).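

In this assay, for the compounds shown here, methyl in place of hydrogen on the amide-type nitrogen in a ring gives a 3.0-fold lower number from compound 3 to compound 4 (0.48 log units; beyond the scatter), and this modest step is the first single-place change in the set to lie beyond the scatter. Going by these compounds alone, the only earlier step, a 1.8-fold higher number from compound 2 to compound 3 (0.26 log units; within the scatter), stayed within the scatter, and every earlier compound kept the amide hydrogen, so this position had not been tested until now. The result shows that the effect in this assay does not depend on keeping the amide hydrogen, and that the number can shift with a change at this nitrogen, although nothing available explains why it does so here.

Methyl is the only group other than hydrogen shown on this nitrogen, so it remains open whether ethyl, a longer chain, a benzyl group or a carboxylic acid on a short chain would move the number further, leave it unchanged or reverse the step. As far as these compounds go, it also remains open whether the same methyl change would give a similar step on compound 1 or compound 2, which differ from compound 3 elsewhere.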